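Chloro in Place of Amino on a Shared Core

The source may hold more compounds than are shown below. What is called first, only, known or untested is meant among the compounds shown, and "the series" means these compounds.

Compound 1 `O=[N+]([O-])c1ccccc1-c1nc2cccnc2o1`: 57%
Compound 2 `Brc1ccccc1-c1nc2cccnc2o1`: 31%
Compound 3 `Nc1ccccc1-c1nc2cccnc2o1`: 13%

Three compounds share one core and differ only in a single group on a six-membered aromatic ring of carbon only. In a functional assay on the whole organism for inhibition, with Rattus norvegicus as the target, at a dose of 30 mg/kg (on this read-out lower numbers stand for less inhibition and higher numbers for more inhibition at the one dose given (going by the name of the read-out)), compound 1 gives 57%, compound 2 gives 31%, and compound 3 gives 13%. Compound 3 stands lowest of the three: its nearest neighbour is compound 2, by a number 18 percentage points lower from compound 2 to compound 3 (beyond the scatter), and the furthest is compound 1, by a number 44 percentage points lower from compound 1 to compound 3 (beyond the scatter).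

Compound 4 `Clc1ccccc1-c1nc2cccnc2o1` is the next step from compound 3: chloro in place of amino on an aromatic carbon. The step that bears most on it is the one where bromo was replaced by amino, a number 18 percentage points lower from compound 2 to compound 3 (beyond the scatter), since chloro and bromo are both halogens on the same aromatic carbon; the larger drop a number 44 percentage points lower from compound 1 to compound 3 (beyond the scatter) also points the same way. Reversing the amino change is therefore expected to raise the number in this assay by a modest amount, roughly back to the level of compound 2. Compound 4 is expected to give 30%, within a range from 15% to 45%. For compound 4 this amounts to an expected a number 17 percentage points higher from compound 3 to compound 4 (beyond the scatter).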

Compound 4, a percentage reported as inhibition, in the whole organism at one dose (the size of the read-out at that dose, not a potency): 50%
Beside the measured number, compound 4's estimate is 20 percentage points below it; the whole stated range lies below it.
By their numbers in this assay, from the lowest: compound 3; then compound 2; then compounds 4 and 1 (each within the scatter of the next).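

Chloro and bromo, though both halogens, are not interchangeable at this aromatic carbon in this assay: the change gives a number 19 percentage points higher from compound 2 to compound 4 (beyond the scatter) and so shows that bromo was a poor guide to chloro. Chloro in place of amino gives a number 37 percentage points higher from compound 3 to compound 4 (beyond the scatter) and thus a large step, while chloro in place of nitro gives a number 7 percentage points lower from compound 1 to compound 4 (within the scatter) and so separates these two groups by no more than the usual scatter. No supporting measurement is available to explain why chloro and bromo differ here.

As far as these compounds go, it remains open whether fluoro or iodo would track chloro or bromo, and whether a methyl or methoxy group, with no halogen or nitrogen, could match chloro and nitro. From the compounds shown here alone, how these compounds would compare at other doses also remains unknown.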